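A few compounds are considered here, and "the series" means these few. Any claim that something is new, unique, unknown or untested is made for them only; others in the source may bear on it.

The measured compounds in an assay on isolated protein for inhibition of malate dehydrogenase, mitochondrial (Sus scrofa), with stated times of 45 min and 30 min; on this read-out higher numbers stand for weaker inhibition and lower numbers for stronger inhibition:

Compound 1, `O=S(=O)(Nc1ccc(-c2nc3ccccc3o2)cc1)c1ccccc1O`, gives only a limit in this assay, > 63000 nM.
Compound 2, `COc1ccc(Cl)cc1S(=O)(=O)Nc1ccc(-c2nc3ccccc3o2)cc1`, gives only a limit in this assay, > 63000 nM.
Compound 3, `O=S(=O)(Nc1ccc(-c2nc3ccccc3o2)cc1)c1ccc(Cl)c(Cl)c1`, gives only a limit in this assay, > 63000 nM.

Compound 1 therefore has no number of its own in this assay, only a limit, and the same holds for the two compounds beside it, as the limit of > 63000 nM in this assay, at which 3 of the 3 values shown sit, shows. The unmeasured compound 4, `O=S(=O)(Nc1ccc(-c2nc3ccccc3o2)cc1)c1ccccc1C(F)(F)F`, differs from compound 1 in one place: trifluoromethyl in place of hydroxy on an aromatic carbon. Among the compounds with values here, the steps that bear on this change are those at the same aryl on the sulfonyl sulfur, a step that the two limits leave unreadable from compound 1 to compound 2, a step that the two limits leave unreadable from compound 1 to compound 3 and a step that the two limits leave unreadable from compound 2 to compound 3; none of them can be sized because every value involved sits at the limit (the limit of > 63000 nM in this assay, at which 3 of the 3 values shown sit). With three changes at this aryl all leaving the read-out at the limit, no step beyond the scatter is expected in this assay for compound 4, and a further limit is the most likely outcome. The estimate for compound 4 is 100000 nM, between 40000 nM and 300000 nM, which means the expected step that the limit leaves unreadable from compound 1 to compound 4.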

Compound 4, half-maximal inhibitory concentration: > 63000 nM
Compound 4: only a limit was reported; the forecaster's own chance of this, stated with the estimate: 85%; the middle value lies beyond the limit too.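

In this assay compound 4 gives > 63000 nM, which is a limit and not a number. No step from compound 1 to compound 4 can be read, and every value stands at one limit: the limit of > 63000 nM in this assay, at which 4 of the 4 values shown sit.

The compounds shown leave open whether any aryl on the sulfonyl sulfur gives a measurable value in this assay.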